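Loss of the amino group from compound 1

The source may report more compounds than this note shows. Statements on the series, on what has been measured and on what is new or still open speak of the compounds shown alone.

Within the data shown here, compound 1 `Nc1nc(Cl)c2ncn(Cc3ccccc3CCl)c2n1` stands highest of the two numbers measured so far in a functional assay on MDA-MB-231 cells (Homo sapiens) for cytotoxicity, read by sulforhodamine B assay, with a stated time of 48 h; on this read-out higher numbers stand for lower toxicity in this test and lower numbers for higher toxicity in this test; in this assay compound 1 gives 63100 nM. Compound 2 `ClCc1ccc(Cn2cnc3c(Cl)nc(Cl)nc32)cc1` gives 7240 nM in this assay, a lower number, and the gap between the two lies beyond the scatter, so compound 2 is the more toxic of the pair in this test. Compound 3 `ClCc1ccccc1Cn1cnc2c(Cl)ncnc21` has not yet been measured in this assay. It differs from compound 1 in one place: hydrogen in place of amino on an aromatic carbon. Among the measured compounds shown here, no measured pair shows this change, so its size cannot be read from the data and the expectation rests on the structural change alone. The step of a 2.5-fold lower number from compound 1 to compound 3 (0.40 log units; beyond the scatter) is expected to run toward a lower number, of modest size. Compound 3 is estimated at 25000 nM in this assay, with a range from 8000 nM to 80000 nM.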

Compound 3, concentration lethal to 50% of the cells: 45700 nM
The estimate for compound 3 lay 1.8-fold (0.26 log units) below the measured number, within the range that was stated.
By their numbers in this assay, from the lowest: compound 2; then compounds 3 and 1 (each within the scatter of the next).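

In this assay, hydrogen in place of amino on an aromatic carbon, between two ring nitrogen atoms, gives a 1.4-fold lower number from compound 1 to compound 3 (0.14 log units; within the scatter), so compound 1 and compound 3 cannot be told apart in this test. Among these compounds, this is the first measured pair to isolate the change, and it shows that the amino group at this position is not required for the level of cytotoxicity seen with compound 1. No supporting data bear on why the two compounds match.

Going by these compounds, whether a methylamino group, a dimethylamino group or a methoxy group on this carbon would also stay within the scatter of compound 3 remains open. On these data alone, it is also open whether amino and hydrogen would match on a compound with the other substitution pattern of compound 2.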